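Benzothiophene Replaces Propyl on the Acylthiourea Carbonyl

The compounds below may be only part of what the source reports. "The series", "measured", "known", "first", "only" and "open" are said of these compounds alone.

Compound 1 `O=C(NC(=S)N1CCc2c(OCCCCCOc3ccc(Cl)cc3)cccc21)c1cccc([N+](=O)[O-])c1`: 12100 nM
Compound 2 `CCCC(=O)NC(=S)N1CCc2c(OCCCCCOc3ccc(Cl)cc3)cccc21`: > 50000 nM

Both compounds share one core and differ only in the group on the carbonyl carbon. In an ADME assay on Huh-7 cells (Homo sapiens) for cytotoxicity (on this read-out higher numbers stand for lower toxicity in this test and lower numbers for higher toxicity in this test), compound 1 gives 12100 nM. For compound 2 this assay reports only a limit, > 50000 nM. So compound 2 stands at the top of the numbers shown, and the step of an at least 4.1-fold higher number from compound 1 to compound 2 (0.61 log units; beyond the scatter) is known only as a lower bound, since one of the two values sits at the limit of > 50000 nM in this assay, at which 1 of the 2 values shown sits.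

Compound 3 `O=C(NC(=S)N1CCc2c(OCCCCCOc3ccc(Cl)cc3)cccc21)c1cc2ccccc2s1` has not been measured. It differs from compound 2 by 1-benzothiophen-2-yl in place of propyl on a carbonyl carbon. For the measured compounds named here, the one measured step that bears on this runs from an aromatic group to propyl and was at least modest; the present change runs the other way, from propyl to a larger aromatic group. A downward step of similar size is therefore expected: an at least 4.1-fold lower number from compound 2 to compound 3 (0.61 log units; beyond the scatter). Compound 3 is estimated at 12000 nM, with a range from 3000 nM to 50000 nM.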

Compound 3, half-maximal cytotoxic concentration: > 50000 nM
Compound 3: only a limit was reported; the forecaster's own chance of this, stated with the estimate: 25%; middle value at least 4.1-fold (0.61 log units) from the limit.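

In this assay compound 3 gives > 50000 nM, and this value is a limit of the assay, not a number. Putting 1-benzothiophen-2-yl in place of 3-nitrophenyl on the carbonyl carbon gives an at least 4.1-fold higher number from compound 1 to compound 3 (0.61 log units; beyond the scatter), so an aromatic group at this position does not by itself bring the number down, and only the 3-nitrophenyl compound, compound 1, has a measured value below the limit. The step between compound 2 and compound 3 cannot be read, and the two compounds cannot be ranked, because both values are limits: the limit of > 50000 nM in this assay, at which 2 of the 3 values shown sit.

From the compounds shown here alone, it remains open whether the lower value of compound 1 goes with its nitro group or with its phenyl ring. A plain phenyl group or a 3-aminophenyl group on the same carbonyl carbon would help separate these two possibilities.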